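This account rests on a few compounds, and the source may have more. Where it says the series, first, only, none or still open, it means among the compounds named here.

Compound 1 `Nc1cc(N)c2nc(-c3ccccc3)c(NCc3ccc(Cl)c(Cl)c3)nc2c1`: 83200 nM
Compound 2 `Nc1cc(N)c2nc(-c3ccccc3)c(Sc3ccc(F)cc3)nc2c1`: 75900 nM
Compound 3 `COc1cc(CNc2nc3cc(N)cc(N)c3nc2-c2ccccc2)cc(OC)c1OC`: 26900 nM

These three compounds share one core and were all tested in a functional assay on SF-539 cells (Homo sapiens) for inhibition, read by sulforhodamine B assay, with a stated time of 48 h; a lower number here means that less compound is tolerated, a higher number that more compound is tolerated. Compound 2 gives 75900 nM there, the second highest of the three numbers. Its nearest neighbour is compound 1, which gives 83200 nM, a gap within the scatter, so the two cannot be told apart. Compound 3, at 26900 nM, lies further off, beyond the scatter, with the lower number.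

The untested compound 4 `Nc1cc(N)c2nc(-c3ccccc3)c(Sc3ccc(Cl)c(Cl)c3)nc2c1` differs from compound 2 in one place: 3,4-dichlorophenyl in place of 4-fluorophenyl on a sulfur. Among the compounds with values here, no measured pair shows this change, so its size cannot be read from the numbers. Compound 1, which also contains a 3,4-dichlorophenyl, gives 83200 nM, close to compound 2, and on that basis only a small step is expected, if any, toward the lower side. The step from compound 2 to compound 4 is estimated at a 1.3-fold lower number from compound 2 to compound 4 (0.10 log units; within the scatter). Compound 4 is thus expected to give about 60000 nM in this assay, within the range 25000 nM to 150000 nM.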

Compound 4, concentration lethal to 50% of the cells: < 100000 nM
Compound 4 was reported as a limit (the forecaster's own chance of this, stated with the estimate: 15%); the middle value is on the limit's open side.
By their numbers in this assay, from the lowest: compound 3; then compounds 2 and 1 (each within the scatter of the next).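

In this assay compound 4 gives < 100000 nM as a limit of the assay and not a number. Within the data shown here, no step from compound 2 to compound 4 can be read from it. The compounds shown leave open whether 3,4-dichlorophenyl in place of 4-fluorophenyl on a sulfur changes the number at all, and in which direction.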